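Dithiocarbamate benzamide series: single-point HeLa antiproliferation notes

The source may report more compounds than this note shows. Statements on the series, on what has been measured and on what is new or still open speak of the compounds shown alone.

Two dithiocarbamate benzamides have been tested so far. Compound 1 `Nc1ccccc1NC(=O)c1ccc(CSC(=S)N2CCN(Cc3ccccn3)CC2)cc1` carries a piperazine bearing a pyridinylmethyl group on the thiocarbonyl carbon; in a functional assay on HeLa cells (Homo sapiens) for antiproliferative activity, read by CCK-8 assay, with a stated time of 72 h, tested at 8 uM (on this read-out higher numbers stand for a stronger effect at the one concentration tested and lower numbers for a weaker effect), compound 1 gives 61.4%. Compound 2 `CN(C(=S)SCc1ccc(C(=O)Nc2ccccc2N)cc1)c1cccnc1` carries a methyl(pyridin-3-yl)amino group at the same place; in this assay compound 2 gives 70.5%. The two numbers lie within the scatter of one another, so neither compound can be set above the other on this read-out.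

Compound 3 `CC1CCCCN1C(=S)SCc1ccc(C(=O)Nc2ccccc2N)cc1` is the next member. It differs from compound 2 in one place: 2-methylpiperidin-1-yl in place of methyl(pyridin-3-yl)amino on a thiocarbonyl carbon. Going by the values given here, no step between measured compounds bears on this change, and the only comparison available, compound 1 against compound 2, shows two numbers within the scatter. The expectation is therefore a step from compound 2 to compound 3 of a number 10.5 percentage points lower from compound 2 to compound 3 (beyond the scatter) in this assay, a change not clearly beyond the scatter, with a slight lean downward. Compound 3 is estimated at 60% in this assay, within 40% to 78%.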

Compound 3, a percentage reported as inhibition, at one concentration (the size of the read-out at that concentration, not a potency): 76.3%
Compound 3: middle estimate off by 16.3 percentage points, on the low side, within the range that was stated.
By their numbers in this assay, from the lowest: compounds 1, 2 and 3 (each within the scatter of the next, the first and the last beyond it).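

In this assay, replacing methyl(pyridin-3-yl)amino with 2-methylpiperidin-1-yl on the thiocarbonyl carbon gives a number 5.8 percentage points higher from compound 2 to compound 3 (within the scatter) and does not separate the two compounds. The read-out at this place therefore does not depend on the six-membered aromatic ring with its hetero atom or on the hydrogen-bond acceptor of the leaving group: a six-membered non-aromatic ring with no such acceptor serves equally well at this single concentration. No measurement shown offers a reason for this result.

The compounds shown leave open whether the methyl group on the ring of compound 3 contributes anything, which a plain piperidin-1-yl or a morpholin-4-yl at the same place would test. Also open, on these data alone, is whether an open-chain group such as diethylamino would hold the read-out at this level.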